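Swapping Chloro for Hydroxy on Two Related Cores

This account rests on a few compounds, and the source may have more. Where it says the series, first, only, none or still open, it means among the compounds named here.

Compound 1, `Cn1c(SCC(=O)Nn2c(COc3ccc(Cl)cc3Cl)nc3ccccc3c2=O)nc(-c2ccc(Cl)cc2)c(C#N)c1=O`: 76.4%
Compound 2, `Cn1c(SCC(=O)Nn2c(COc3ccc(Cl)cc3Cl)nc3ccccc3c2=O)nc(-c2ccc(O)cc2)c(C#N)c1=O`: 80%
Compound 3, `N#Cc1c(Nc2ccccc2)nc(SCC(=O)Nn2c(COc3ccc(Cl)cc3Cl)nc3ccccc3c2=O)nc1-c1ccc(Cl)cc1`: 43.6%

All three were tested in a functional assay on the whole organism (strain albino) for inhibition, with Rattus norvegicus as the target, read by paw edema, with a stated time of 1 h, at a dose of 100 mg/kg by the oral route; a lower number here means less inhibition, a higher number more inhibition at the dose given (going by the name of the read-out). Compound 1 and compound 2 share one core and differ only in one place: hydroxy in place of chloro on an aromatic carbon. That change made a step of a number 3.6 percentage points higher from compound 1 to compound 2 (within the scatter), so the two readings cannot be told apart. Compound 3 sits on a different core, and the difference between the two cores is not broken down here. Compared with compound 1 and compound 2, compound 3 gives a markedly lower inhibition, with both gaps beyond the usual scatter.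

Compound 4, `N#Cc1c(Nc2ccccc2)nc(SCC(=O)Nn2c(COc3ccc(Cl)cc3Cl)nc3ccccc3c2=O)nc1-c1ccc(O)cc1`, has not yet been measured. It relates to compound 3 exactly as compound 2 relates to compound 1: hydroxy in place of chloro on an aromatic carbon. The place of the change is described in the same words in both pairs, so this is the same change carried onto the second core.

Because the earlier step was a number 3.6 percentage points higher from compound 1 to compound 2 (within the scatter), the expected step from compound 3 to compound 4 is small, a number 3.4 percentage points higher from compound 3 to compound 4 (within the scatter). Compound 4 is therefore expected to land near compound 3, at an estimated 47% in this assay. The estimate for compound 4 is expected to fall between 30% and 63%, allowing for the wider uncertainty of carrying one observed step onto a different core.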

Compound 4, a percentage reported as inhibition, in the whole organism at one dose (the size of the read-out at that dose, not a potency): 90.9%
The estimate for compound 4 lay 43.9 percentage points below the measured number; the measured number lies above the stated range.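

On the core of compound 3, putting 4-hydroxyphenyl in place of 4-chlorophenyl gave in this assay a step of a number 47.3 percentage points higher from compound 3 to compound 4 (beyond the scatter) and so changed the reading far more than the same swap did on the other core. These two pairs, each read at a single oral dose and a single time, do not show why the size of the step depends on the core, and they give no rule for predicting the step on any further core. What they do show is that, in this series, a small step seen on one core cannot simply be assumed to hold on another, even when the change itself is identical: the same change on two cores in this assay, a number 3.6 percentage points higher (within the scatter) from compound 1 to compound 2 and a number 47.3 percentage points higher (beyond the scatter) from compound 3 to compound 4, 43.7 percentage points apart, beyond the scatter of two such steps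

The compounds shown leave open how other groups, such as an amine, a methoxy group or a carboxylic acid, would read in the place held here by chloro or hydroxy on either core. They also leave open whether a third core would follow the small step, the large step or neither, and whether the gap between the two steps would persist at other doses or times.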